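Trading acetyl for tert-butyl on a tetrachloro-cyclopentadienylidene hydrazine

The source may hold more compounds than are shown below. What is called first, only, known or untested is meant among the compounds shown, and "the series" means these compounds.

Compound 1 `CC(=O)NN=C1C(Cl)=C(Cl)C(Cl)=C1Cl` carries an acetyl group on the hydrazine nitrogen. In a functional assay on MM1.S cells (Homo sapiens) for cytotoxicity, read by MTT assay, with a stated time of 48 h (on this read-out higher numbers stand for weaker inhibition and lower numbers for stronger inhibition), compound 1 has no single number to its name: its entry reads "not determined" (no result reported). Compound 2 `C#CCOC(=O)NN=C1C(Cl)=C(Cl)C(Cl)=C1Cl` likewise stands without a result, "not determined" (no result reported). Only compound 3 `CC(C)(C)C(=O)NN=C1C(Cl)=C(Cl)C(Cl)=C1Cl` gives a figure, 2000 nM in this assay. Compound 4 `CC(C)(C)NN=C1C(Cl)=C(Cl)C(Cl)=C1Cl` has yet to be measured, and it differs from compound 1 by tert-butyl in place of acetyl on an amine nitrogen. Among the compounds with values here, no step between measured compounds exists to size this change. Compound 3, the nearest relative with a number, suggests the shared core tolerates a bulky group at this position, so the step into compound 4 is expected to be small in this assay, within the scatter or slightly weaker. Compound 4 is therefore estimated at 3000 nM, with a range from 600 nM to 15000 nM.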

Compound 4, half-maximal inhibitory concentration: > 3000 nM
Compound 4 gave a limit, no number (the forecaster's own chance of this, stated with the estimate: 25%); the middle value lies on the limit itself.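

In this assay compound 4 gives only a limit, > 3000 nM, and not a number. Within the data shown here, compound 1 has no single number either, so no step between compound 1 and compound 4 can be read. The compounds shown leave open what trading acetyl for tert-butyl does to cytotoxicity.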